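This account rests on a few compounds, and the source may have more. Where it says the series, first, only, none or still open, it means among the compounds named here.

Compound 1 `CC(C)Cc1ccc2c(NCCCNCc3ccco3)ccnc2c1` was examined in a physicochemical assay for acid dissociation, and in this assay compound 1 gives 9.47. Compound 2 `FC(F)(F)c1cc(-c2ccc3c(NCCCNCc4ccco4)ccnc3c2)cc(C(F)(F)F)c1` gives 9.47, level with compound 1 at the digits shown, the two values lying within the scatter of each other. Compound 3 `c1coc(CNCCCNc2ccnc3cc(CC4CCCCC4)ccc23)c1` has not yet been measured in this assay. It differs from compound 1 by cyclohexyl in place of isopropyl on a saturated chain carbon bound to an aromatic carbon. No step beyond the scatter is expected from this change in this assay. The expected step of no change at the digits printed from compound 1 to compound 3 (within the scatter) is therefore essentially none. Compound 3 is accordingly estimated at 9.47, with an expected range from 9.15 to 9.8.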

Compound 3, acid dissociation constant: 9.47
The estimate for compound 3 equals the measured number at the digits printed, and the stated range covers the measured number.
By their numbers in this assay, from the lowest: compounds 1, 2 and 3 (each within the scatter of the next).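

In this assay, within the data shown here, the exchange of isopropyl for cyclohexyl on a saturated chain carbon bound to an aromatic carbon gives a step of no change at the digits printed from compound 1 to compound 3 (within the scatter) and is the first comparison here of compounds differing in one place. At this position, a six-membered non-aromatic ring of carbon only, with six heavy atoms entering where three leave, brings no step beyond the scatter. Nothing available explains this result.

As far as these compounds go, whether the same holds for an amine or a carboxylic acid at this position stays open. So does the outcome for a longer chain.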